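Removing the amide methyl: from one core to another

The source may hold more compounds than are shown below. What is called first, only, known or untested is meant among the compounds shown, and "the series" means these compounds.

Of the compounds shown here, three have been tested in a functional assay on the whole organism with Mus musculus as the target, at a dose of 100 mg/kg by the intraperitoneal route; on this read-out lower numbers stand for less inhibition and higher numbers for more inhibition at the one dose given (going by the name of the read-out). Compound 1 `CNC(=O)/C=C1\CCc2cc(F)c(F)cc21` gives 100% in this assay, and compound 3 `NC(=O)/C=C1\CCc2cc(F)c(F)cc21` gives 100%. Compound 2 `CNC(=O)/C=C1\CCc2ccc(Br)cc21` gives 0%, the lowest of the three numbers, beyond the scatter from both compound 1 and compound 3. The difference between the core of compound 1 and the core of compound 2 is not broken down here.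

Compound 3 differs from compound 1 by hydrogen in place of methyl on an amide-type nitrogen, and the step of no change at the digits printed from compound 1 to compound 3 (within the scatter). Compound 4 `NC(=O)/C=C1\CCc2ccc(Br)cc21` has not yet been measured; it differs from compound 2 by hydrogen in place of methyl on an amide-type nitrogen. This is the same change at the same place, and it occurs twice among the compounds shown.

The expected step of a number 10 percentage points higher from compound 2 to compound 4 (within the scatter) in this assay rests on compound 2 giving 0% and on the earlier pair, where no change at the digits printed from compound 1 to compound 3 (within the scatter). Compound 4 is therefore estimated at 10% in this assay, between 0% and 50%. The range is kept wide: compound 1 and compound 3 both sit at the top of the read-out, which leaves room for a difference the pair does not show.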

Compound 4, a percentage reported as inhibition, in the whole organism at one dose (the size of the read-out at that dose, not a potency): 100%
Compound 4: the middle estimate sits 90 percentage points below what was measured, and the stated range ends below it.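

In this assay, the removal of the amide methyl does not carry over from one core to the other as a fixed step: the same change on two cores in this assay, no change at the digits printed (within the scatter) from compound 1 to compound 3 and a number 100 percentage points higher (beyond the scatter) from compound 2 to compound 4, 100 percentage points apart, beyond the scatter of two such steps On the core of compound 2 the change gives a number 100 percentage points higher from compound 2 to compound 4 (beyond the scatter), so hydrogen in place of methyl on an amide-type nitrogen matters on this core, even though it left no visible mark on the core of compound 1. This does not show that the change is without effect on the core of compound 1, as compound 1 gives 100% and compound 3 gives 100%, where a difference could stay hidden, and two pairs tested at a single dose give neither an explanation nor a rule for other cores.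

The compounds shown leave open whether an ethyl group or a longer chain on an amide-type nitrogen would follow the methyl on either core. They also leave open which part of the difference between the two cores separates the two steps.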